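Cytotoxicity notes: aryl sulfanyl in place of furanyl

This account rests on a few compounds, and the source may have more. Where it says the series, first, only, none or still open, it means among the compounds named here.

Of the compounds shown here, three have been tested in an ADME assay on HEL cells (Homo sapiens) for cytotoxicity, with a stated time of 3 days; on this read-out lower numbers stand for higher toxicity in this test and higher numbers for lower toxicity in this test. Compound 2 `Cc1cc(-c2ccco2)c2ncc(CSCCc3ccccc3)n2c1` gives 100 ug/mL and compound 3 `Cc1cc(-n2cccc2)c2ncc(CSCc3ccccc3)n2c1` gives 100 ug/mL; these two are level within the scatter and together stand highest of the three. Compound 1 `Cc1cc(Sc2ccc(O)cc2)cn2c(CSCCc3ccccc3)cnc12`, which also bears a (4-hydroxyphenyl)sulfanyl group, gives 4 ug/mL, a number far lower than that of compound 2 and beyond the scatter. Compound 4 `Cc1cc(Sc2ccc(O)cc2)c2ncc(CSCCc3ccccc3)n2c1` is not yet measured; it differs from compound 2 by (4-hydroxyphenyl)sulfanyl in place of furan-2-yl on an aromatic carbon. Among the measured compounds shown here, no step between measured compounds is available to scale this change directly. The step expected a 5.0-fold lower number from compound 2 to compound 4 (0.70 log units; beyond the scatter) is toward a lower number, of moderate size, since compound 1 sits at 4 ug/mL. Compound 4 is estimated at 20 ug/mL, with a range of 4 ug/mL to 100 ug/mL.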

Compound 4, minimum cytotoxic concentration: > 100 ug/mL
Compound 4 ended at the assay's limit (the forecaster's own chance of this, stated with the estimate: 20%); middle value at least 5.0-fold (0.69 log units) from the limit.
By their numbers in this assay, from the lowest: compound 1; then compounds 2 and 3 (each within the scatter of the next).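

Compound 4 gives > 100 ug/mL in this assay, and this value is a limit of the assay, not a number. On this aromatic carbon, (4-hydroxyphenyl)sulfanyl in place of furan-2-yl gives a number no lower from compound 2 to compound 4 (the limit leaves the size open), so this change brings no drop on the read-out. The size of the step cannot be read: the limit of > 100 ug/mL in this assay, at which 1 of the 4 values shown sits.

The compounds shown leave open what the hydroxyl contributes to this result, as a phenylsulfanyl group without it or a methoxy group in its place would show. From the compounds shown here alone, whether an amine or a carboxylic acid on the same carbon would also keep the read-out at the limit remains unknown.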